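The source may hold more compounds than are shown below. What is called first, only, known or untested is meant among the compounds shown, and "the series" means these compounds.

Of the compounds shown here, three that share one core have been measured so far: compound 1 (`Fc1ccc(-c2ccc(-c3ccc(-c4nc5ccccc5[nH]4)cc3)cc2)cc1`), compound 2 (`FC(F)(F)Oc1ccc(-c2ccc(-c3ccc(-c4nc5ccccc5[nH]4)cc3)cc2)cc1`) and compound 3 (`CN(C)c1ccc(-c2ccc(-c3ccc(-c4nc5ccccc5[nH]4)cc3)cc2)cc1`). In a functional assay on MCF7 cells (Homo sapiens) for inhibition, read by sulforhodamine B assay (on this read-out higher numbers stand for weaker inhibition of growth and lower numbers for stronger inhibition of growth), compound 1 gives 36200 nM, compound 2 gives 38400 nM and compound 3 gives 41200 nM. These values lie within the usual scatter of one another, so compound 1 holds no separate place among them. Compound 4 (`Oc1cccc2[nH]c(-c3ccc(-c4ccc(-c5ccc(F)cc5)cc4)cc3)nc12`) has not yet been measured. It differs from compound 1 as follows: hydroxy in place of hydrogen on an aromatic carbon. In words, this is hydroxy in place of hydrogen on an aromatic carbon, in a six-membered aromatic ring of carbon only that is part of a fused or bridged system of two rings. The measured steps are a 1.1-fold higher number from compound 1 to compound 2 (0.03 log units; within the scatter), a 1.1-fold higher number from compound 1 to compound 3 (0.06 log units; within the scatter) and a 1.1-fold higher number from compound 2 to compound 3 (0.03 log units; within the scatter). All three exchange the group that is fluoro in compound 1, so they bear on this change only indirectly. Going by the values given here, they show that those exchanges left the read-out within the scatter, but no measured compound carries a new group at the carbon that takes the hydroxy. No clear direction can therefore be drawn from the data, and no step beyond the scatter is expected. The expected step is a 1.2-fold lower number from compound 1 to compound 4 (0.08 log units; within the scatter), although this remains uncertain. For compound 4, the estimated value is 30000 nM, with an expected range from 10000 nM to 70000 nM.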

Compound 4, concentration for 50% growth inhibition: 3010 nM
Compound 4: middle estimate off by 10-fold (1.00 log units), on the high side; measured number below the stated range.
By their numbers in this assay, from the lowest: compound 4; then compounds 1, 2 and 3 (each within the scatter of the next).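

In this assay, placing a hydroxy group on an aromatic carbon of the six-membered aromatic ring of carbon only, ortho to a fused ring and meta to a fused ring, gives a 12-fold lower number from compound 1 to compound 4 (1.08 log units; beyond the scatter) and so marks a large step towards stronger inhibition of growth. Going by these compounds alone, the earlier compounds differed only in the group that is fluoro in compound 1, and all their steps stayed within the scatter, so the read-out had not yet moved with any structural change; this position is the first place where one small exchange clearly shifts it. The data shown offer no measurement that accounts for the size of this step.

As far as these compounds go, it remains open whether the effect belongs to hydroxy itself or would also appear with another group on this carbon, such as methoxy, an amine or a carboxylic acid. From the compounds shown here alone, it is also open whether hydroxy on other carbons of the same ring would give a similar step, and whether this step would hold with trifluoromethoxy or dimethylamino in place of fluoro.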